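A few compounds are considered here, and "the series" means these few. Any claim that something is new, unique, unknown or untested is made for them only; others in the source may bear on it.

Going by the values given here, compound 1 `O=C(NCc1ccc(F)cc1)c1nc(Br)c2cccnc2c1NCCCNc1c(C(=O)NCc2ccc(F)cc2)nc(Br)c2cccnc12` and compound 2 `C[C@@H](Nc1c(C(=O)NCc2ccc(F)cc2)nc(Br)c2cccnc12)c1ccccc1` are the two measured members, both tested in a functional assay on HCT-116 cells (Homo sapiens) for cytotoxicity, read by MTT assay, with a stated time of 72 h; a higher number here means a weaker inhibitor, a lower number a stronger inhibitor. In this assay compound 1 returns only a limit, > 20000 nM, and no number. In the same assay compound 2 also returns only a limit, > 20000 nM, and no number. Among the compounds with values here, compound 2 thus stands at the limit of the assay, the same place as the one other value shown, so that the limit of > 20000 nM in this assay, at which 2 of the 2 values shown sit, describes the whole of the measured data. Within the data shown here, no step between measured compounds can be computed, and nothing can be said of how compound 1 and compound 2 compare with each other.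

Compound 3 `Cc1ccc(S(=O)(=O)Oc2c(C(=O)NCc3ccc(F)cc3)nc(Br)c3cccnc23)cc1` has not been measured. It differs from compound 2 in one place: ((4-methylphenyl)sulfonyl)oxy in place of (1-phenylethyl)amino on an aromatic carbon. The (1-phenylethyl)amino that leaves carries 1 hydrogen-bond donor and 1 defined stereocentre; the ((4-methylphenyl)sulfonyl)oxy that enters carries 0 hydrogen-bond donors and 3 hydrogen-bond acceptors. With both measured compounds at the limit, no direction for this change can be read from the data, and the expectation is a step no larger than the scatter, with compound 3 most likely again reported only as a limit: an estimated step that the limit leaves unreadable from compound 2 to compound 3 in this assay. Compound 3 is therefore expected near 25000 nM, within 8000 nM to 80000 nM.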

Compound 3, half-maximal inhibitory concentration: > 20000 nM
Compound 3 was reported as a limit; the forecaster's own chance of this, stated with the estimate: 75%; the middle value does not contradict the limit.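

In this assay compound 3 gives > 20000 nM as a limit and not a number. Going by these compounds alone, no step between compound 2 and compound 3 can be read from this result. The compounds shown leave open which change to the shared core, if any, would give this assay a measured number rather than a limit.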